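A few compounds are considered here, and "the series" means these few. Any claim that something is new, unique, unknown or untested is made for them only; others in the source may bear on it.

Measured compounds:
- compound 1 `COc1ccc(Nc2nccc(-c3sc(N(C)C)nc3C)n2)c(OC)c1` gives 170 nM in a functional assay on MV4-11 cells (Homo sapiens) for inhibition, read by resazurin assay, with a stated time of 72 h; a higher number here means a weaker inhibitor of growth, a lower number a stronger inhibitor of growth
- compound 2 `COc1ccc(Nc2nccc(-c3c[nH]c4ccccc34)n2)c(OC(F)F)c1` gives 4770 nM in this assay

Of the compounds shown here, two have been measured in this assay, and they sit far apart. Compound 1 has the lower of the two numbers, so it is the stronger inhibitor of growth of the pair. Compound 2 is a different molecule in more than one place, and its number lies well beyond the usual scatter from that of compound 1. Among the compounds with values here, no pair of measured compounds differs in only one place, so no single change has yet been followed on its own.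

Within the data shown here, compound 3 `CCCSc1nc(C)c(-c2ccnc(Nc3ccc(OC)cc3OC)n2)s1` is the first such single change, starting from compound 1: propylsulfanyl in place of dimethylamino on an aromatic carbon. The shared core and the other substituents are kept. Among the measured compounds shown here, nothing measured so far shows what this exchange does, so the expectation rests on compound 1 alone. The step of a 2.4-fold higher number from compound 1 to compound 3 (0.37 log units; beyond the scatter) is expected to be small, most likely toward a somewhat higher number, and it may well fall within the scatter. Compound 3 is estimated at 400 nM, with a range from 100 nM to 1500 nM.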

Compound 3, concentration for 50% growth inhibition: 2240 nM
Compound 3: the middle estimate sits 5.6-fold (0.75 log units) below what was measured; the measured number lies above the stated range.
By their numbers in this assay, from the lowest: compound 1; then compound 3; then compound 2.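

In this assay, the substituent on this aromatic carbon, next to the ring nitrogen and next to the ring sulfur, clearly matters: propylsulfanyl in place of dimethylamino gives a 13-fold higher number from compound 1 to compound 3 (1.12 log units; beyond the scatter) and makes the compound a much weaker inhibitor of growth. The core and the other substituents stay the same, so this single exchange accounts for the whole step. The two groups have the same counts of hydrogen-bond donors and acceptors, and neither has a ring or a net charge, so these shared features do not keep the number low, and no measurement shown here explains why it rises.

One exchange changes the nitrogen to a sulfur and alters the chain at the same time, so the compounds shown cannot say which of these matters more. A methylsulfanyl group, a propoxy chain or a cyclic amine such as morpholine at this position would help to separate those two changes and show how much room the position allows.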